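Replacing the Aminopyrimidine Ring on the Carbonyl Carbon

A few compounds are considered here, and "the series" means these few. Any claim that something is new, unique, unknown or untested is made for them only; others in the source may bear on it.

Two measured compounds share a core and differ only in the ring attached to the carbonyl carbon. Compound 1 `COc1ccc(-c2cc3ccccc3nc2/C=C/C(=O)c2ccc(N)cc2)cc1` carries 4-aminophenyl there, and in a functional assay on NCI-H1299 cells (Homo sapiens) for antiproliferative activity, read by XTT assay, with a stated time of 72 h (on this read-out higher numbers stand for weaker inhibition and lower numbers for stronger inhibition), compound 1 gives 6510 nM. Compound 2 `COc1ccc(-c2cc3ccccc3nc2/C=C/C(=O)c2cnc(N)nc2C)cc1` carries 2-amino-4-methylpyrimidin-5-yl instead. In this assay compound 2 gives > 10000 nM, which is a limit of the assay rather than a number. This is the limit of > 10000 nM in this assay, at which 1 of the 2 values shown sits. The step of an at least 1.5-fold higher number from compound 1 to compound 2 (0.18 log units; that floor lies within the scatter) is therefore known only as a floor, and compound 2 stands at that limit with no exact figure.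

Compound 3 `COc1ccc(-c2cc3ccccc3nc2/C=C/C(=O)c2c[nH]c3ccccc23)cc1` carries the next change: 1H-indol-3-yl in place of 2-amino-4-methylpyrimidin-5-yl on a carbonyl carbon. Among the compounds with values here, no measured step involves an indole on the carbonyl carbon, so the only guide is compound 1, which with 4-aminophenyl gave 6510 nM. Compound 3 is expected to return to a measurable number, so the step of an at least 2.5-fold lower number from compound 2 to compound 3 (0.39 log units; beyond the scatter) is expected as a decrease, though its size is uncertain. The estimate for compound 3 in this assay is 4000 nM, with a range from 800 nM to 20000 nM.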

Compound 3, half-maximal inhibitory concentration: > 10000 nM
Compound 3 ended at the assay's limit (the forecaster's own chance of this, stated with the estimate: 30%); at least 2.5-fold (0.39 log units) between middle value and limit.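

In this assay compound 3 gives > 10000 nM, which is a limit of the assay and not a number. Set against 4-aminophenyl, 1H-indol-3-yl on the carbonyl carbon gives an at least 1.5-fold higher number from compound 1 to compound 3 (0.18 log units; that floor lies within the scatter), so this floor alone does not separate the two rings, and the true gap could be small or large. The step between the two compounds at the limit cannot be read, which leaves 1H-indol-3-yl and 2-amino-4-methylpyrimidin-5-yl unranked against each other, and two different rings on the carbonyl carbon now end in the same place: the limit of > 10000 nM in this assay, at which 2 of the 3 values shown sit.

Still open, from the compounds shown here alone, is whether any ring at this position can give a clearly lower number than compound 1, as 4-aminophenyl is the only ring here with an exact figure. Also open, going by these compounds, is how a plain phenyl ring, or a phenyl ring carrying a carboxylic acid in place of the amine, would read, and so whether the amine of compound 1 matters at all.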